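Chloro to Amino on a Fused Core: One Step, Two Settings

This account rests on a few compounds, and the source may have more. Where it says the series, first, only, none or still open, it means among the compounds named here.

Compound 1 `Nc1nc(Cl)c2ncn(Cc3ccc(CCl)cc3)c2n1`: 42700 nM
Compound 2 `ClCc1cccc(Cn2cnc3c(Cl)nc(Cl)nc32)c1`: 5120 nM
Compound 3 `ClCc1ccc(Cn2cnc3c(Cl)nc(Cl)nc32)cc1`: 25100 nM

All three were tested in a functional assay on NCI-H322M cells (Homo sapiens) for cytotoxicity, read by sulforhodamine B assay, with a stated time of 48 h; a lower number here means a stronger inhibitor of growth, a higher number a weaker inhibitor of growth. Compound 2 gives the lowest number of the three, and its gaps to compound 3 and to compound 1 both lie beyond the usual scatter, so it is the strongest growth inhibitor here. Compound 3 and compound 1 differ by one change, (amino in place of chloro on an aromatic carbon), and the step of a 1.7-fold higher number from compound 3 to compound 1 (0.23 log units; within the scatter) is one the assay cannot tell from repetition. Compound 4 `Nc1nc(Cl)c2ncn(Cc3cccc(CCl)c3)c2n1` is not yet measured; it differs from compound 2 by amino in place of chloro on an aromatic carbon, the same change at the same kind of place. How the core of compound 2 differs from the core of compound 3 is not broken down here. Because compound 3 to compound 1 showed a 1.7-fold higher number from compound 3 to compound 1 (0.23 log units; within the scatter), the step of a 1.7-fold higher number from compound 2 to compound 4 (0.23 log units; within the scatter) is expected to be of similar size. Compound 4 is therefore estimated at 8700 nM in this assay, with a likely range from 3500 nM to 22000 nM.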

Compound 4, concentration for total growth inhibition: 22400 nM
Compound 4: middle estimate off by 2.6-fold (0.41 log units), on the low side; measured number above the stated range.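

In this assay, putting amino in place of chloro on the aromatic carbon of the core of compound 2 gives a 4.4-fold higher number from compound 2 to compound 4 (0.64 log units; beyond the scatter), so on this core the amino compound is the weaker inhibitor of growth. Set beside the same change on the other core, the two steps are no further apart than repeated measurements could make them: the same change on two cores in this assay, a 1.7-fold higher number (0.23 log units; within the scatter) from compound 3 to compound 1 and a 4.4-fold higher number (0.64 log units; beyond the scatter) from compound 2 to compound 4, 2.6-fold (0.41 log units) apart, within the scatter of two such steps. The change therefore carries across these two cores as far as the data can tell, but two steps, one of them too small to read on its own, do not fix its true size or show that it would hold on any further core.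

The compounds shown carry only chloro or amino on that aromatic carbon, so what a methoxy, a hydroxyl or a methylamino group would do there remains open. As far as these compounds go, whether the step keeps its size in other cell lines also remains open.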